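The compounds below may be only part of what the source reports. "The series", "measured", "known", "first", "only" and "open" are said of these compounds alone.

Measured compounds:
- compound 1 `CCOC(=O)C(C)Oc1cc(O)c2c(=O)c(O)c(-c3ccc(OC)cc3)oc2c1CC=C(C)C`: 1400 nM
- compound 2 `COc1ccc(-c2oc3c(CC=C(C)C)c(OC(C)C(=O)O)cc(O)c3c(=O)c2O)cc1`: 19300 nM
- compound 3 `COc1ccc(-c2oc3c(CC=C(C)C)c(OCC(=O)O)cc(O)c3c(=O)c2O)cc1`: "not determined" (no result reported)

In an ADME assay on Vero cells (Chlorocebus sabaeus) for cytotoxicity, read by MTT assay (on this read-out higher numbers stand for weaker inhibition and lower numbers for stronger inhibition), compound 2 gives 19300 nM and compound 1 gives 1400 nM. The change from compound 2 to compound 1 is ethyl in place of hydrogen on an oxygen next to a carbonyl group, and this step is a 14-fold lower number from compound 2 to compound 1 (1.14 log units; beyond the scatter). For compound 3 the entry in this assay is "not determined" (no result reported), so no number is known. Compound 3 differs from compound 2 by hydrogen in place of methyl on a saturated chain carbon bound to a carbonyl carbon and an oxygen on an aromatic ring. Compound 4 `CCOC(=O)COc1cc(O)c2c(=O)c(O)c(-c3ccc(OC)cc3)oc2c1CC=C(C)C` is not yet measured; it differs from compound 3 by ethyl in place of hydrogen on an oxygen next to a carbonyl group, the same change as that from compound 2 to compound 1, at a place described in the same words. Within the data shown here, the step from compound 3 to compound 4 is expected to be of a size like the one from compound 2 to compound 1, which rests only on that single pair. Because compound 1 gives 1400 nM, compound 4 is estimated at 2000 nM, with a range of 500 nM to 10000 nM.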

Compound 4, half-maximal inhibitory concentration: 1400 nM
Beside the measured number, compound 4's estimate is 1.4-fold (0.15 log units) above it; low and high end bracket the measured number.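

Among these compounds, compound 3 has no number in this assay, and the step from it to compound 4 cannot be read, which leaves a 14-fold lower number from compound 2 to compound 1 (1.14 log units; beyond the scatter) as the only direct reading of the ethyl change. On these data alone, the steps that can be read show no change at the digits printed from compound 1 to compound 4 (within the scatter) and a 14-fold lower number from compound 2 to compound 4 (1.14 log units; beyond the scatter), so hydrogen in place of methyl on the chain carbon makes no visible difference between the two ethoxycarbonyl compounds, while its effect on the carboxy compounds stays unknown. No measured finding bears on why these steps have this size.

Still open, as far as these compounds go, is how butyl in place of ethyl on the same oxygen would read in this assay. From the compounds shown here alone, an amide in place of the ethoxycarbonyl group is equally open.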